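Swapping a nitro for an isopropyl on compound 1

The compounds below may be only part of what the source reports. "The series", "measured", "known", "first", "only" and "open" are said of these compounds alone.

Measured so far:
compound 1, `Cc1cnc(Nc2ccc([N+](=O)[O-])cc2)nc1Nc1nc2ccccc2s1`: 22500 nM
compound 2, `CS(=O)(=O)c1ccc(Nc2nccc(Nc3nc4ccccc4s3)n2)cc1`: 5910 nM
compound 3, `Cc1ccc2nc(Nc3nc(Nc4ccc(S(C)(=O)=O)cc4)ncc3F)sc2c1`: 14300 nM

In a functional assay on MDA-MB-231 cells (Homo sapiens) for antiproliferative activity, read by MTT assay, with a stated time of 48 h (on this read-out higher numbers stand for weaker inhibition and lower numbers for stronger inhibition), compound 1 gives the highest of the three numbers. Compound 3 sits within the scatter of compound 1, so those two cannot be told apart, while compound 2 gives a number beyond the scatter below compound 1.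

Compound 4, `Cc1cnc(Nc2ccc(C(C)C)cc2)nc1Nc1nc2ccccc2s1`, has not yet been measured. It differs from compound 1 in one place only: isopropyl in place of nitro on an aromatic carbon. Among the compounds with values here, no measured pair shows this exact change, so there is nothing to lean on beyond the structures themselves. The expected step is a 1.6-fold lower number from compound 1 to compound 4 (0.21 log units; within the scatter), which leans toward a lower number without clearly leaving the scatter. In this assay compound 4 is therefore estimated at 14000 nM, with a range from 4000 nM to 50000 nM.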

Compound 4, half-maximal inhibitory concentration: > 50000 nM
Compound 4: only a limit was reported; the forecaster's own chance of this, stated with the estimate: 10%; middle value at least 3.5-fold (0.55 log units) from the limit.
By their numbers in this assay, from the lowest: compound 2; then compounds 3 and 1 (each within the scatter of the next). At a limit, above all of these: compound 4.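

In this assay compound 4 gives > 50000 nM, which is a limit and not a number. Even so, going from 4-nitrophenyl to 4-isopropylphenyl gives an at least 2.2-fold higher number from compound 1 to compound 4 (0.34 log units; beyond the scatter). This first single-place step shows that the group on this aromatic carbon can shift the read-out, even between two groups with the same count of heavy atoms.

Nothing shown tells how an amine or a carboxylic acid on this carbon would read. As far as these compounds go, it also remains open whether the same change on the core of compound 2 would give a similar step.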